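The compounds below may be only part of what the source reports. "The series", "measured", "known", "first", "only" and "open" are said of these compounds alone.

In a functional assay on PC-3 cells (Homo sapiens) for cytotoxicity, read by resazurin assay, with a stated time of 48 h (a lower number here means a stronger inhibitor, a higher number a weaker inhibitor), compound 1 `C=C(C)[C@@H]1CC=C(CN(OC)C2OC[C@@H](O)[C@H](O)[C@H]2O)CC1` gives 152000 nM as its half-maximal inhibitory concentration. Compound 2 `C=C(C)[C@@H]1CC=C(CN(OC)C2OC[C@@H](N=[N+]=[N-])[C@H](O)[C@H]2O)CC1` gives 170000 nM in the same test. For the measured compounds named here, these two numbers lie within the usual scatter of each other, so compound 1 stands level with the only other compound measured so far.

Compound 3 `C=CCOC(=O)NC[C@H]1OC(N(CC2=CC[C@@H](C(=C)C)CC2)OC)[C@H](O)[C@@H](O)[C@@H]1O` keeps the core of compound 1 but changes it in one place. The change is ((allyloxycarbonyl)amino)methyl in place of hydrogen on a saturated ring carbon and in words it puts ((allyloxycarbonyl)amino)methyl in place of hydrogen on a saturated ring carbon, next to the ring oxygen.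

Going by the values given here, only one measured step bears on this, and it is a loose guide. Azido in place of hydroxy on a saturated ring carbon gave a 1.1-fold higher number from compound 1 to compound 2 (0.05 log units; within the scatter) and so moved nothing beyond the scatter. Among the compounds with values here, that step swaps one group for another, while compound 3 gains a whole chain that no measured compound carries. Within the data shown here, with the step to compound 2 at a 1.1-fold higher number from compound 1 to compound 2 (0.05 log units; within the scatter) as the sole evidence, this assay is expected to show no clear shift and no firm direction. The expected change is a 1.3-fold lower number from compound 1 to compound 3 (0.10 log units; within the scatter) as an estimate only. For compound 3 the estimated value is 120000 nM with an expected range from 40000 nM to 300000 nM.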

Compound 3, half-maximal inhibitory concentration: 232000 nM
Compound 3: the middle estimate sits 1.9-fold (0.29 log units) below what was measured, and the stated range covers the measured number.
By their numbers in this assay, from the lowest: compounds 1, 2 and 3 (each within the scatter of the next).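

In this assay, ((allyloxycarbonyl)amino)methyl in place of hydrogen on a saturated ring carbon, next to the ring oxygen, gives a 1.5-fold higher number from compound 1 to compound 3 (0.18 log units; within the scatter), so the two compounds stand level. For the compounds shown here, the earlier pair showed only one group swapped for another on the ring, whereas this pair shows that a chain of 8 heavy atoms can be added to the core of compound 1 at this carbon without a reading that can be told apart from the parent. The chain also brings no gain in inhibition, and this assay's number stays in the same high range that compound 1 shows at 152000 nM. Nothing available here accounts for this result.

The compounds shown leave open whether a small free amine such as aminomethyl, or a carboxylic acid, on this same ring carbon would move the number beyond the usual scatter of the measurement. They also leave open whether a longer chain, or one ending in a phenyl ring instead of the allyl group, would change the reading in this assay at this position.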